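The source may hold more compounds than are shown below. What is called first, only, known or untested is meant among the compounds shown, and "the series" means these compounds.

Compound 1 `O=C(CSc1nnnn1-c1ccccc1)N/N=c1/scc(-c2ccc(Br)cc2)n1-c1ccccc1` and compound 2 `Cc1ccc(-c2cs/c(=N/NC(=O)CSc3nnnn3-c3ccccc3)n2-c2ccccc2)cc1` share one core and differ only at one aromatic carbon. In a functional assay on C6 cells (Rattus norvegicus) for cytotoxicity, read by MTT assay, with a stated time of 24 h, tested at 100 ug/mL (on this read-out lower numbers stand for a stronger effect and higher numbers for a weaker effect at the one concentration tested), compound 1 gives 24.3%, and in this assay compound 2 gives 28.5%. Of the two numbers shown, compound 2 stands at the upper end, separated from compound 1 by a number 4.2 percentage points higher from compound 1 to compound 2 (within the scatter), so the two cannot be told apart on this read-out.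

Compound 3 `Cc1ccc(-c2cs/c(=N/NC(=O)CSc3nncn3C)n2-c2ccccc2)cc1` is not yet measured. It differs from compound 2 in 4-methyl-4H-1,2,4-triazol-3-yl in place of 1-phenyl-1H-tetrazol-5-yl on a sulfur. Among the compounds with values here, no measured step touches this sulfur; the one step known, the swap of methyl for bromo on an aromatic carbon, was within the scatter and bears only loosely on the new change. Without a step at this place, no shift beyond the scatter is expected, and the estimated step is a number 0.5 percentage points higher from compound 2 to compound 3 (within the scatter). Compound 3 is therefore expected to give about 29%, with a range from 14% to 48%.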

Compound 3, a percentage reported as activity, at one concentration (the size of the read-out at that concentration, not a potency): 39.6%
Compound 3: middle estimate off by 10.6 percentage points, on the low side; low and high end bracket the measured number.
By their numbers in this assay, from the lowest: compounds 1 and 2 (each within the scatter of the next); then compound 3.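

The group on the sulfur does affect this read-out: in this assay, 4-methyl-4H-1,2,4-triazol-3-yl in place of 1-phenyl-1H-tetrazol-5-yl gives a number 11.1 percentage points higher from compound 2 to compound 3 (beyond the scatter), which means a weaker effect at the one concentration tested. The earlier change of methyl for bromo on an aromatic carbon gave a number 4.2 percentage points higher from compound 1 to compound 2 (within the scatter), so this sulfur substituent is the only place shown where a change exceeds the scatter. No measurement shown here explains the shift.

This swap changes the five-membered aromatic ring and also removes the six-membered aromatic ring, so the compounds shown leave open which of these differences matters. A 4-phenyl-4H-1,2,4-triazol-3-yl or a 1-methyl-1H-tetrazol-5-yl group on the same sulfur would separate the two.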